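The compounds below may be only part of what the source reports. "The series", "measured", "known", "first", "only" and "open" are said of these compounds alone.

Compound 1 `Cc1ccc(-c2ccc(C)n2-c2ccc(-c3nc4ccccc4s3)cc2)cc1`: 3100 nM
Compound 2 `COc1ccc(-c2ccc(C)n2-c2ccc(-c3nc4ccccc4s3)cc2)cc1`: 3260 nM
Compound 3 `Cc1ccc(-c2ccc([N+](=O)[O-])cc2)n1-c1ccc(-c2nc3ccccc3s2)cc1`: 3110 nM

All three were tested in a functional assay on MCF7 cells (Homo sapiens) for cytotoxicity, read by MTT assay, with a stated time of 72 h; a lower number here means a stronger inhibitor, a higher number a weaker inhibitor. Their numbers sit close together: the steps of a 1.1-fold higher number from compound 1 to compound 2 (0.02 log units; within the scatter) and a 1.0-fold higher number from compound 1 to compound 3 (0.00 log units; within the scatter) both stay within the scatter, so compound 1 stands level with the other two rather than apart from them. Compound 4 `COc1ccc2nc(-c3ccc(-n4c(C)ccc4-c4ccc(C)cc4)cc3)sc2c1` has not yet been measured in this assay. It differs from compound 1 by methoxy in place of hydrogen on an aromatic carbon. Going by the values given here, none of the measured steps touches that ring; they only swap groups elsewhere in the molecule, and none of them moved the number beyond the scatter. Among the compounds with values here, with no directly comparable step, the expectation is a step of no change at the digits printed from compound 1 to compound 4 (within the scatter), that is, no change beyond the scatter. Compound 4 is therefore estimated at 3100 nM, with a range from 1400 nM to 7000 nM.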

Compound 4, half-maximal inhibitory concentration: 2850 nM
Compound 4: the middle estimate sits 1.1-fold (0.04 log units) above what was measured; the range from low to high includes it.
By their numbers in this assay, from the lowest: compounds 4, 1, 3 and 2 (each within the scatter of the next).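

This is the first change shown on the six-membered aromatic ring of carbon only that belongs to the fused system: in this assay, methoxy in place of hydrogen there gives a 1.1-fold lower number from compound 1 to compound 4 (0.04 log units; within the scatter) and stays within the scatter. The position therefore takes methoxy with no clear shift, much as the swaps elsewhere in the molecule did. No measurement here explains this result. Going by these compounds, whether an amine, a carboxylic acid or a longer chain such as butoxy at this position would move the number beyond the scatter remains open.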